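The source may hold more compounds than are shown below. What is called first, only, known or untested is meant among the compounds shown, and "the series" means these compounds.

Among the measured compounds shown here, compound 1 `COc1cc(OC)c(-c2coc3cc(OCc4ccccc4F)ccc3c2=O)cc1OC` gives 2890 nM in a functional assay on U-251 cells (Homo sapiens) for antiproliferative activity, read by MTT assay, with a stated time of 24 h (on this read-out higher numbers stand for weaker inhibition and lower numbers for stronger inhibition), and stands highest of the two numbers measured so far; compound 2 `COc1cc(OC)c(-c2coc3cc(OCc4ccccc4C#N)ccc3c2=O)cc1OC` gives 980 nM, a step of a 2.9-fold lower number from compound 1 to compound 2 (0.47 log units; beyond the scatter). Compound 3 `COc1cc(OC)c(-c2coc3cc(OCc4cccc(Cl)c4)ccc3c2=O)cc1OC` differs from compound 1 by 3-chlorophenyl in place of 2-fluorophenyl on a saturated chain carbon bound to an oxygen on an aromatic ring. For the measured compounds named here, no measured step shares this change: the one step known, from compound 1 to compound 2, puts a different group on that ring, so it is only a loose guide. Compound 3 is therefore expected to give about 2000 nM, with a range from 800 nM to 5000 nM. The expected step of a 1.4-fold lower number from compound 1 to compound 3 (0.16 log units; within the scatter) is small and uncertain.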

Compound 3, half-maximal inhibitory concentration: > 10000 nM
Compound 3: a limit, no number; the forecaster's own chance of this, stated with the estimate: 5%; at least 5.0-fold (0.69 log units) between middle value and limit.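

Compound 3 gives a limit, not a number, in this assay: the limit of > 10000 nM in this assay, at which 1 of the 3 values shown sits. The earlier step showed only a lower number at this place, whereas on the saturated chain carbon bound to an oxygen on an aromatic ring, 3-chlorophenyl brings an at least 3.4-fold higher number from compound 1 to compound 3 (0.53 log units; beyond the scatter) and an at least 10-fold higher number from compound 2 to compound 3 (1.00 log units; beyond the scatter). This place therefore tolerates some groups far less well than others in this cell read-out.

In compound 3, the halogen and the name of the phenyl group change together, and the compounds shown do not separate these two changes. As far as these compounds go, how an amine or a carboxylic acid on that phenyl would read also stays open.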